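The source may hold more compounds than are shown below. What is called first, only, known or untested is meant among the compounds shown, and "the series" means these compounds.

Compound 1 `CCOC(=O)c1c(-c2cccc(Cl)c2)[nH]c2cccc(OC)c2c1=O` and compound 2 `CCOC(=O)c1c(-c2ccccc2C)[nH]c2cc(OC)ccc2c1=O` were both examined in a physicochemical assay for solubility, in phosphate buffer, at pH 7.4; a higher number here means a more soluble compound, a lower number a less soluble compound. In this assay compound 1 returns > 100000 nM, which is a limit of the assay rather than a number. Compound 2 likewise returns > 100000 nM, again a limit and not a number. Compound 2 thus stands at the limit of > 100000 nM in this assay, at which 2 of the 2 values shown sit, and its place within the soluble region cannot be fixed more closely. Compound 3 `CCOC(=O)c1c(-c2cccc([N+](=O)[O-])c2)[nH]c2cc(OC)ccc2c1=O` has not yet been measured in this assay. It differs from compound 2 at one point: 3-nitrophenyl in place of 2-methylphenyl on an aromatic carbon. For the measured compounds named here, no step between measured compounds is available, so the change must be judged from the structures alone; a step of no more than the usual scatter is expected, leaning if anything toward lower solubility. For compound 3 the expected value in this assay is 100000 nM, within 30000 nM to 300000 nM, which corresponds to an expected step of a number no higher from compound 2 to compound 3 (the limit leaves the size open).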

Compound 3, solubility: 13000 nM
Compound 3: middle estimate off by 7.7-fold (0.89 log units), on the high side, outside the stated range (below it).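

In this assay, the group on this aromatic carbon, next to the ring nitrogen and ortho to the ethoxycarbonyl group, proves able to move the read-out: 3-nitrophenyl in place of 2-methylphenyl gives an at least 7.6-fold lower number from compound 2 to compound 3 (0.88 log units; beyond the scatter). The earlier compounds shown here could not show this, as both stood at the limit and neither gave a number. The value of compound 2 is itself only a limit, so the step has a floor but no known full size: the limit of > 100000 nM in this assay, at which 2 of the 3 values shown sit.

The compounds shown leave open whether the lower number goes with the nitro group itself, with its place on the phenyl ring, or with the loss of the 2-methyl group. They also do not tell how an amine or a carboxylic acid on that phenyl ring would read.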